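Phenoxy for phenyl on two styrene-type cores in PANC-1 growth inhibition

The compounds below may be only part of what the source reports. "The series", "measured", "known", "first", "only" and "open" are said of these compounds alone.

Compound 1 `CC(C)(C)OC(=O)N1CCC[C@H]1COCCCCCC/C=C/c1ccc(-c2ccccc2)cc1` is inactive up to the assay limit in a functional assay on PANC-1 cells (Homo sapiens) for inhibition, read by XTT assay, with a stated time of 72 h (a lower number here means a stronger inhibitor, a higher number a weaker inhibitor), where compound 1 gives > 100000 nM. Compound 2 `CC(C)(C)OC(=O)N1CCC[C@H]1COCCCCCC/C=C/c1ccc(Oc2ccccc2)cc1` carries the change phenoxy in place of phenyl on an aromatic carbon and in this assay compound 2 gives 63300 nM. The step of an at least 1.5-fold lower number from compound 1 to compound 2 (0.19 log units; that floor lies within the scatter) can only be given as a floor, because compound 1 sits at the limit of > 100000 nM in this assay, at which 2 of the 3 values shown sit.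

Compound 3 `Cc1ccc([S+]([O-])N2CCC[C@H]2COCCCCCCCCC/C=C/c2ccc(-c3ccccc3)cc2)cc1` also stands at the limit: in this assay compound 3 gives > 100000 nM. The difference between the core of compound 3 and the core of compound 1 is not broken down here.

Compound 4 `Cc1ccc([S+]([O-])N2CCC[C@H]2COCCCCCCCCC/C=C/c2ccc(Oc3ccccc3)cc2)cc1` is not yet measured; it differs from compound 3 by phenoxy in place of phenyl on an aromatic carbon, the same change as between compound 1 and compound 2, at the same place. Within the data shown here, for compound 4 a step of an at least 1.4-fold lower number from compound 3 to compound 4 (0.15 log units; that floor lies within the scatter) is expected in this assay, resting on the single earlier step of an at least 1.5-fold lower number from compound 1 to compound 2 (0.19 log units; that floor lies within the scatter), which itself is only a floor. Compound 4 is estimated at 70000 nM, with a range from 30000 nM to 200000 nM, and a real chance that compound 4 again reads only as a limit.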

Compound 4, half-maximal inhibitory concentration: > 100000 nM
Compound 4 was reported as a limit (the forecaster's own chance of this, stated with the estimate: 50%); middle value at least 1.4-fold (0.15 log units) away from the limit.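

In this assay compound 4 gives > 100000 nM, a limit of the assay. Compound 3 also stands at a limit, so no step between compound 3 and compound 4 can be read: the limit of > 100000 nM in this assay, at which 3 of the 4 values shown sit.

Still open, from the compounds shown here alone, is whether phenoxy in place of phenyl lowers the number at all on the core of compound 3.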